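Configuration at the Chain Carbon and Adenosine Receptor Binding

A few compounds are considered here, and "the series" means these few. Any claim that something is new, unique, unknown or untested is made for them only; others in the source may bear on it.

Measured compounds:
Compound 1: `CCCSc1nc(NC(C)=O)cc(O[C@H](C)c2ccccc2)n1`, 1.7 nM
Compound 2: `CCCSc1nc(NC(C)=O)cc(OC(C)c2ccccc2)n1`, 0.6 nM

Both compounds were tested in an assay on CHO cells for displacement of a labelled ligand from adenosine receptor A3 (Homo sapiens), with a stated time of 180 min; on this read-out lower numbers stand for stronger inhibition and higher numbers for weaker inhibition. Compound 1 gives 1.7 nM, and compound 2 gives 0.6 nM, the lowest of the two numbers. The only thing that separates them is how the stereocentre at the saturated chain carbon is drawn: R in compound 1, without a configuration in compound 2. That single step, a 2.8-fold lower number from compound 1 to compound 2 (0.45 log units; beyond the scatter), lies beyond the scatter, and the fact that the fact that one of compounds 1 and 2 is drawn with a defined configuration and the other without, at the place where they differ is the one point of difference between them is the only clue to its origin.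

Compound 3 is `CCCSc1nc(NC(C)=O)cc(O[C@@H](C)c2ccccc2)n1`. Its change from compound 2 is the two compounds have the same atoms and bonds; at least one stereo element is drawn with a configuration in one of them and without one in the other: 1 of 1 stereo elements differ; a stereocentre at a saturated chain carbon is drawn without a configuration in compound 2 and S in compound 3. Since compound 2 is drawn without a configuration, it can be read as a mixture of the two drawn forms, and compound 1, the R form, gives a higher number than compound 2; the S form would then be expected to give a lower number than compound 2, roughly mirroring a 2.8-fold lower number from compound 1 to compound 2 (0.45 log units; beyond the scatter) in the other direction. For compound 3 the estimate in this assay is therefore 0.4 nM, with a range from 0.15 nM to 1.2 nM, meaning an expected step of a 1.5-fold lower number from compound 2 to compound 3 (0.18 log units; within the scatter).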

Compound 3, inhibition constant: 0.5 nM
Compound 3: the middle estimate sits 1.3-fold (0.10 log units) below what was measured; measured number inside the range.
By their numbers in this assay, from the lowest: compounds 3 and 2 (each within the scatter of the next); then compound 1.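

The earlier pair could only set one drawn form against a compound drawn without a configuration. Now the R and S forms can be compared directly in this assay, and their difference, a 3.4-fold lower number from compound 1 to compound 3 (0.53 log units; beyond the scatter), lies beyond the scatter and can be tied to the configuration at the saturated chain carbon: the fact that compounds 1 and 3 differ only in the configuration as drawn. The other new step, a 1.2-fold lower number from compound 2 to compound 3 (0.08 log units; within the scatter), lies within the scatter, so this read-out cannot tell the S form from the compound drawn without a configuration. At this position, then, the R form alone stands apart, with the highest number of the three compounds, although the gap is only modest.

The compounds shown leave open whether the S form keeps this edge over the R form when an ethyl group takes the place of the methyl group on the chain carbon. They also leave open whether the same gap between the two forms appears at other adenosine receptors.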